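Swapping the aryl group on the shared core

The source may report more compounds than this note shows. Statements on the series, on what has been measured and on what is new or still open speak of the compounds shown alone.

In a functional assay on ECa-109 cells (Homo sapiens) for antiproliferative activity, read by MTT assay, with a stated time of 72 h (on this read-out higher numbers stand for weaker inhibition and lower numbers for stronger inhibition), compound 1 `CCCSc1nc(N/N=C/c2ccccc2F)c2nnn(Cc3ccccc3)c2n1` reaches only the limit of the assay, giving > 64000 nM. Compound 2 `CCCSc1nc(N/N=C/c2ccc(C)cc2)c2nnn(Cc3ccccc3)c2n1` likewise stops at a limit, > 64000 nM. The step that the two limits leave unreadable from compound 1 to compound 2 therefore cannot be read, since (the limit of > 64000 nM in this assay, at which 2 of the 3 values shown sit). Going by the values given here, compound 3 `CCCSc1nc(N/N=C(\C)c2ccccc2O)c2nnn(Cc3cccc(Cl)c3)c2n1` is the one measured compound with a number, 13000 nM. Compound 4 `CCCSc1nc(N/N=C/c2c(O)ccc3ccccc23)c2nnn(Cc3ccccc3)c2n1` differs from compound 1 by 2-hydroxynaphthalen-1-yl in place of 2-fluorophenyl on a carbon with a double bond to nitrogen. Among the compounds with values here, no measured step makes this change, so nothing bears on it directly; compounds 1 and 2 both stopped at the limit, while compound 3 gave a number. Compound 4 is expected to land somewhat below the limit, with the estimated step of an at least 4.2-fold lower number from compound 1 to compound 4 (0.63 log units; beyond the scatter). The estimate for compound 4 is 15000 nM, between 3000 nM and 64000 nM.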

Compound 4, half-maximal inhibitory concentration: 9290 nM
Beside the measured number, compound 4's estimate is 1.6-fold (0.21 log units) above it, and the stated range covers the measured number.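

Going by these compounds alone, on the carbon with a double bond to nitrogen, 2-hydroxynaphthalen-1-yl gives the first readable change at this position in this assay: an at least 6.8-fold lower number from compound 1 to compound 4 (0.83 log units; beyond the scatter), and an at least 6.8-fold lower number from compound 2 to compound 4 (0.83 log units; beyond the scatter). So an aryl swap here can bring the read-out off the limit, which the two earlier compounds could not show. Both steps give only a minimum size because compound 1 and compound 2 stop at a limit: the limit of > 64000 nM in this assay, at which 2 of the 4 values shown sit.

This change brings in an extra aromatic ring and a hydroxy group together, and the compounds shown do not tell which of the two goes with the step. Plain naphthalen-1-yl or 2-methoxynaphthalen-1-yl on the same core would separate them.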